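A few compounds are considered here, and "the series" means these few. Any claim that something is new, unique, unknown or untested is made for them only; others in the source may bear on it.

Compound 1 `Fc1ccc(CSc2nc(-c3ccc(Br)cc3)cc(-c3ccc(Br)cc3)n2)cc1` and compound 2 `Fc1cccc(CSc2nc(-c3ccc(Br)cc3)cc(-c3ccc(Br)cc3)n2)c1` share one core and differ only in the fluorophenyl group, 4-fluorophenyl against 3-fluorophenyl. In an assay on isolated protein for inhibition of Alpha glucosidase (Homo sapiens), read by spectrophotometry, with stated times of 15 min and 30 min (a higher number here means a weaker inhibitor, a lower number a stronger inhibitor), compound 1 gives 19000 nM, and compound 2 gives 19000 nM. The step of no change at the digits printed from compound 1 to compound 2 (within the scatter) shows that this exchange left the reading unchanged. Compound 2 thus stands level with compound 1 on the numbers in hand, with no other measured neighbour. Compound 3 `Clc1ccccc1CSc1nc(-c2ccc(Br)cc2)cc(-c2ccc(Br)cc2)n1` carries the change (2-chlorophenyl in place of 3-fluorophenyl on a saturated chain carbon bound to a sulfur). Among the compounds with values here, the only measured step that bears on it is no change at the digits printed from compound 1 to compound 2 (within the scatter), a change of the fluorophenyl group on the same chain carbon with no effect beyond the scatter. Within the data shown here, a change of halogen at the same place has no precedent here, so the nearest evidence points to no step beyond the scatter in this assay. The expected step is no change at the digits printed from compound 2 to compound 3 (within the scatter). Compound 3 is therefore expected to give 19000 nM, within a range of 8000 nM to 45000 nM.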

Compound 3, half-maximal inhibitory concentration: 19000 nM
The estimate for compound 3 equals the measured number at the digits printed; measured number inside the range.
By their numbers in this assay, from the lowest: compounds 1, 2 and 3 (each within the scatter of the next).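

In this assay, 2-chlorophenyl on a saturated chain carbon bound to a sulfur gives no change at the digits printed from compound 2 to compound 3 (within the scatter) and no change at the digits printed from compound 1 to compound 3 (within the scatter), so the record at this place now holds a change of halogen as well as the exchange of 4-fluorophenyl for 3-fluorophenyl. Among these three compounds, the read-out does not separate 4-fluorophenyl, 3-fluorophenyl and 2-chlorophenyl. No supporting measurement bears on why the readings coincide.

On these data alone, whether the same reading holds for a group without halogen, such as unsubstituted phenyl, or for an aminophenyl or carboxyphenyl group at this place remains open. The 4-bromophenyl groups are common to all three compounds, so these compounds cannot show what an exchange of those groups would do.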